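The source may report more compounds than this note shows. Statements on the series, on what has been measured and on what is new or still open speak of the compounds shown alone.

Of the compounds shown here, two have been measured so far. Compound 1, with the structure `COC(=O)c1ccc(OCCCCOc2ccc(C(=O)CC3CCCC3)c(C)c2C)cc1`, gives a largest response of 24.2% in an assay on HEK293 cells for positive allosteric modulation of metabotropic glutamate receptor 3 (Rattus norvegicus), read by thallium flux, with a stated time of 2.5 min; a lower number here means a smaller maximal response, a higher number a larger maximal response. Compound 2, with the structure `Cc1cc(OCCCCOc2ccc(C(=O)CC3CCCC3)c(O)c2C)ccc1C(=O)O`, gives 23.7% in this assay. Of the two numbers shown, compound 2 carries the one that sits at the bottom, yet compound 1 lies within the usual scatter of it, so the two cannot be told apart on these data.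

Compound 3, with the structure `Cc1ccc(C(=O)O)cc1OCCCCOc1ccc(C(=O)CC2CCCC2)c(O)c1C`, has not yet been measured. It is built from the same atoms as compound 2, joined differently: 5-carboxy-2-methylphenyl in place of 4-carboxy-3-methylphenyl on an oxygen on a saturated carbon. The carboxylic acid and the methyl group thus trade their positions on the same aromatic ring, while the rest of the molecule is kept.

For the measured compounds named here, no step between measured compounds exists to guide this change. Compound 1 and compound 2 differ at two places and still agree within the scatter, which gives no sign that such edits move the largest response much. The step from compound 2 to compound 3 is therefore expected to be about a number 0.3 percentage points higher from compound 2 to compound 3 (within the scatter), none beyond the scatter. Compound 3 is estimated to give 24% in this assay, within a range from 12% to 38%.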

Compound 3, largest response reached (reported as percent of maximum), in percent of the reference or control that the assay uses: 26.9%
Estimate against measurement, compound 3: 2.9 percentage points below, and the stated range covers the measured number.
By their numbers in this assay, from the lowest: compounds 2, 1 and 3 (each within the scatter of the next).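

In this assay, for the compounds shown here, the first comparison that differs in only one place gives a number 3.2 percentage points higher from compound 2 to compound 3 (within the scatter). The group attached to the oxygen on a saturated carbon keeps the same atoms and the same counted features, so this step tests only their arrangement: 5-carboxy-2-methylphenyl against 4-carboxy-3-methylphenyl. The carboxylic acid and the methyl group can therefore trade places on this ring without a difference in largest response that these data can resolve, although this single pair cannot show whether the same would hold with any other group or on a different core. No evidence is available that bears on this result, so it cannot be explained from what is shown.

On these data alone, the arrangements tested here all keep a carboxylic acid and a methyl group on this ring, so it remains open whether a different group would take the response beyond the scatter. A tetrazole or an amide in place of the carboxylic acid, or a chlorine atom in place of the methyl group, would address that question directly.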